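Piperidinyl swap on the amine chain of compound 2

A few compounds are considered here, and "the series" means these few. Any claim that something is new, unique, unknown or untested is made for them only; others in the source may bear on it.

Among the measured compounds shown here, in a functional assay on the whole organism for inhibition, with Mus musculus as the target (on this read-out lower numbers stand for an effect already at smaller amounts and higher numbers for an effect only at larger amounts of compound), compound 3 `CCCCCc1ccc2nc(O)oc2c1` gives 80.7 mg/kg as the only exact number so far. Compound 1 `CCCCC(=O)c1ccc2c(c1)sc(=O)n2CCN(C)C` reads > 70 mg/kg in this assay and this is a limit. On these data alone, compound 2 `CCC(=O)c1ccc2c(c1)sc(=O)n2CCN(C)C` reads > 130 mg/kg and this is also a limit, so its exact standing stays open. For the measured compounds named here, the one measured step that the two limits leave unreadable from compound 1 to compound 2 lies on a different chain and gives no size to carry over. Compound 4 `CCC(=O)c1ccc2c(c1)sc(=O)n2CCN1CCCCC1` differs by piperidin-1-yl in place of dimethylamino on a saturated chain carbon, two bonds along the chain from an aromatic nitrogen on a saturated chain carbon, two bonds along the chain from an aromatic nitrogen. Going by the values given here, no measured step covers this change, so the expected step that the limit leaves unreadable from compound 2 to compound 4 stays within the scatter. For compound 4 the estimate is 140 mg/kg and the expected range runs from 70 mg/kg to 280 mg/kg in this assay.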

Compound 4, dose for half-maximal effect: > 55 mg/kg
Compound 4 gave a limit, no number; the forecaster's own chance of this, stated with the estimate: 55%; the middle value lies beyond the limit too.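

Compound 2 and compound 4 both stand only as limits, so the step from dimethylamino to piperidin-1-yl cannot be read. The compounds shown leave open the size and direction of this swap on the amine chain.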